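The source may hold more compounds than are shown below. What is called first, only, known or untested is meant among the compounds shown, and "the series" means these compounds.

Compound 1 `O=C(/C=C/CCCCCCc1ccccc1)N1CCC(O)CC1`: > 100000 nM
Compound 2 `O=C(CCCCCCCCCc1ccccc1)N1CCCCC1`: > 100000 nM
Compound 3 `O=C(CCCOCCCCc1ccccc1)N1CCCCC1`: > 100000 nM

In a functional assay on PANC-1 cells (Homo sapiens) for cytotoxicity, read by WST assay, with a stated time of 24 h (a higher number here means a weaker inhibitor, a lower number a stronger inhibitor), compound 1 reaches only the limit of the assay, > 100000 nM. Compound 2 likewise reaches only the limit, > 100000 nM. Compound 3 returns the same limit, > 100000 nM. Compound 2 thus stands at the limit of this assay rather than at a number, as do the two other values in hand, so that the limit of > 100000 nM in this assay, at which 3 of the 3 values shown sit, describes every measurement made so far.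

The unmeasured compound 4 `O=C(CCCCCCCCC1CCCCC1)N1CCCCC1` differs from compound 2 in one place: cyclohexyl in place of benzyl on a saturated chain carbon, eight bonds along the chain from a carbonyl carbon. Among the compounds with values here, no step between two measured compounds is available to gauge this change in this assay. With compound 2 and both other measured compounds resting at the limit, the change is expected to leave the result within the scatter, a step that the limit leaves unreadable from compound 2 to compound 4. Compound 4 is therefore expected to come out at 150000 nM, in the range 50000 nM to 500000 nM, most probably again as a limit rather than a number.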

Compound 4, half-maximal inhibitory concentration: > 100000 nM
Compound 4: a limit, no number; the forecaster's own chance of this, stated with the estimate: 85%; the middle value does not contradict the limit.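

Compound 2 and compound 4 both rest at a limit, and no size can be read for the step from benzyl to cyclohexyl. The compounds shown leave open which structure, if any, would give a number rather than a limit in this assay.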